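Cyclopropyl replaces difluorophenyl at the imidazole-borne chain carbon

A few compounds are considered here, and "the series" means these few. Any claim that something is new, unique, unknown or untested is made for them only; others in the source may bear on it.

Compound 3 `O=C(O)c1ccccc1-c1ccc(CCc2ncc(Cc3cccc(F)c3F)[nH]2)cc1` holds the lowest number of the three compounds in an in vitro functional assay on cells for agonist activity at Bombesin receptor subtype-3 (Homo sapiens), read by luminescence and calcium flux (a lower number here means that less compound is needed, a higher number that more compound is needed for the effect), giving 87 nM. Compound 1 `O=C(O)c1ccccc1-c1ccc(CCc2ncc(CC3CCOCC3)[nH]2)cc1` gives 338 nM and compound 2 `Cc1ccc(Cc2cnc(CCc3ccc(-c4ccccc4C(=O)O)cc3)[nH]2)cc1` gives 2660 nM. Compound 4 `O=C(O)c1ccccc1-c1ccc(CCc2ncc(CC3CC3)[nH]2)cc1` differs from compound 3 by cyclopropyl in place of 2,3-difluorophenyl on a saturated chain carbon bound to an aromatic carbon. Going by the values given here, the closest precedent is the opposite move from a saturated ring to this aryl group, which gave a 3.9-fold lower number from compound 1 to compound 3 (0.59 log units; beyond the scatter); the aryl-to-aryl swap gave a 31-fold lower number from compound 2 to compound 3 (1.49 log units; beyond the scatter) and bears less directly. A saturated ring in this position is therefore expected to cost potency, and compound 4 is estimated at 400 nM (range 150 nM to 1200 nM), meaning an expected step of a 4.6-fold higher number from compound 3 to compound 4 (0.66 log units; beyond the scatter), likely landing near compound 1.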

Compound 4, half-maximal effective concentration: 1000 nM
Compound 4: middle estimate off by 2.5-fold (0.40 log units), on the low side; the measured number falls inside the stated range.
By their numbers in this assay, from the lowest: compound 3; then compound 1; then compound 4; then compound 2.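

In this assay, the aryl groups do not form one block against the saturated rings at this position: cyclopropyl gives an 11-fold higher number from compound 3 to compound 4 (1.06 log units; beyond the scatter), yet also a 2.7-fold lower number from compound 2 to compound 4 (0.42 log units; beyond the scatter), so compound 4 falls between the two aryl compounds. The two saturated rings also differ, with a 3.0-fold higher number from compound 1 to compound 4 (0.47 log units; beyond the scatter). Nothing measured here explains these steps.

As far as these compounds go, whether a cyclohexyl ring or an amine on this saturated chain carbon would give a lower or a higher number remains open. So does what separates 2,3-difluorophenyl from 4-methylphenyl.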